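Replacing methyl with nitro on compound 3

The source may report more compounds than this note shows. Statements on the series, on what has been measured and on what is new or still open speak of the compounds shown alone.

Of the compounds shown here, three sharing one core have been tested in a functional assay on HeLa cells (Homo sapiens) for antiproliferative activity, read by MTT assay, with a stated time of 72 h; on this read-out higher numbers stand for weaker inhibition and lower numbers for stronger inhibition. Compound 1 `CCCn1ccnc1-c1cc(OC)c(OC)c(OC)c1`, with propyl on an aromatic nitrogen, reads > 100000 nM, which is a limit and not a number. Compound 2 `CCCCn1ccnc1-c1cc(OC)c(OC)c(OC)c1`, with butyl in that place, reads > 100000 nM, again a limit. For the measured compounds named here, compound 3 `COc1cc(-c2nccn2-c2cccc(C)c2)cc(OC)c1OC`, with 3-methylphenyl there, gives the only true number so far, 1900 nM.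

The next compound, compound 4 `COc1cc(-c2nccn2-c2cccc([N+](=O)[O-])c2)cc(OC)c1OC`, has nitro in place of methyl on an aromatic carbon. Both steps with a readable size changed the group on the nitrogen, from a chain to 3-methylphenyl: an at least 52-fold lower number from compound 1 to compound 3 (1.72 log units; beyond the scatter) and an at least 52-fold lower number from compound 2 to compound 3 (1.72 log units; beyond the scatter). Compound 4 keeps an aromatic ring on that nitrogen, so a fall back to the limit is not the likeliest outcome. Neither step varies a group on that ring, however, so they give no direct guide to the effect of this swap, and no direction can be favoured with confidence. The expected change, which is no more than the scatter, is a 1.3-fold higher number from compound 3 to compound 4 (0.12 log units; within the scatter). For compound 4 the estimated value is 2500 nM, within an expected range of 350 nM to 18000 nM.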

Compound 4, half-maximal inhibitory concentration: 6700 nM
Estimate against measurement, compound 4: 2.7-fold (0.43 log units) below, and the stated range covers the measured number.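

For the compounds shown here, the earlier compounds changed only the group on the aromatic nitrogen, while this is the first change on the ring carried there, and in this assay it gives a 3.5-fold higher number from compound 3 to compound 4 (0.55 log units; beyond the scatter). This aromatic carbon is therefore not indifferent to what it carries, although the step is modest, and with nitro in this place the compound still gives a true number, so inhibition is weakened without being lost from the readable range. Nitro brings more heavy atoms and more hydrogen-bond acceptors than methyl, but nothing shown ties the step to either difference.

From the compounds shown here alone, with only methyl and nitro on this aromatic carbon, two groups make no trend, and how plain hydrogen, chlorine, a methoxy group or an amine would read in the same place remains open. Both groups also sit on the same carbon of that ring, so whether the same swap on another carbon of the ring would give a step of similar size and direction is equally unsettled.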